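A few compounds are considered here, and "the series" means these few. Any claim that something is new, unique, unknown or untested is made for them only; others in the source may bear on it.

Going by the values given here, compound 1 `C=CC(=O)Nc1cc(C(F)(F)F)cc(C(F)(F)F)c1` is the only compound of this set with a numerical result: in an ADME assay for pharmacokinetics, read by LC-MS, in phosphate buffer, with a stated time of 72 h, at pH 7.4, tested at 250 uM (a higher number here means that the compound lasts longer, a lower number that the compound disappears faster), compound 1 gives 1.8 h. Compound 2 `C=CC(=O)Oc1cc(C(F)(F)F)cc(C(F)(F)F)c1` returns only a limit of this assay, < 0.017 h. Among the compounds with values here, the one measured step, an at least 100-fold lower number from compound 1 to compound 2 (2.02 log units; beyond the scatter), is described as (vinylcarbonyl)oxy in place of (vinylcarbonyl)amino on an aromatic carbon, and it runs into (the limit of < 0.017 h in this assay, at which 1 of the 2 values shown sits), so the true size of that drop is not known.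

Compound 3 `N#Cc1cc(C(F)(F)F)cc(C(F)(F)F)c1` differs from compound 1 in a different way: cyano in place of (vinylcarbonyl)amino on an aromatic carbon. Here the whole vinylcarbonyl is gone rather than exchanged at its attaching atom, so the measured step does not cover this change directly; it only shows that this assay is sensitive to what sits at that aromatic carbon and that the number can move by a large amount. With the (vinylcarbonyl)amino removed, the step of a 56-fold higher number from compound 1 to compound 3 (1.74 log units; beyond the scatter) is expected to be a large rise rather than a fall. The half-life of compound 3 is therefore estimated at 100 h, with a range from 20 h to 500 h, and the assay may well report only a limit.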

Compound 3, half-life: > 50 h
Compound 3: no number, only a limit; the forecaster's own chance of this, stated with the estimate: 70%; the middle value lies beyond the limit too.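

In this assay compound 3 gives > 50 h, which is a limit of the assay and not a number. Putting cyano in place of the whole (vinylcarbonyl)amino gives an at least 27-fold higher number from compound 1 to compound 3 (1.44 log units; beyond the scatter), and putting it in place of the (vinylcarbonyl)oxy gives an at least 2900-fold higher number from compound 2 to compound 3 (3.46 log units; beyond the scatter); the compounds shown now reach both ends of what the assay can report, with compound 1 the only one that gives a number. The earlier pair showed only that a change at this aromatic carbon can lower the half-life, whereas this result shows that a change there can also raise it, and the true size of both new steps stays unknown, as each rests on a limit: the limit of > 50 h in this assay, at which 1 of the 3 values shown sits.

From the compounds shown here alone, it remains open whether the rise goes with losing the double bond of the vinylcarbonyl or with losing the whole group, a question that a propanoylamino group at the same carbon, with its saturated chain, would help to separate. Going by these compounds, how a simple amine or a carboxylic acid at this carbon would behave in this assay also remains open.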